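A few compounds are considered here, and "the series" means these few. Any claim that something is new, unique, unknown or untested is made for them only; others in the source may bear on it.

Measured in an ADME assay on a cell-free system (plasma, Mus musculus) (on this read-out higher numbers stand for a larger free fraction and lower numbers for a smaller free fraction), so far:
- compound 1 `CCCS(=O)(=O)c1cccc(C#Cc2cc(Cl)ccc2OCC(=O)O)c1` gives 0.024
- compound 2 `CN(C)S(=O)(=O)c1cncc(C#Cc2cc(Cl)ccc2OCC(=O)O)c1` gives 0.034
- compound 3 `Cc1ccc(S(=O)(=O)NC(C)C)cc1C#Cc1cc(Cl)ccc1OCC(=O)O` gives 0.01

Compound 3 has the lowest of the three values, beyond the scatter from both compound 1 and compound 2. Compound 4 `Cc1ccc(S(C)(=O)=O)cc1C#Cc1cc(Cl)ccc1OCC(=O)O` has methyl in place of isopropylamino on a sulfonyl sulfur. Within the data shown here, no measured pair differs in one place only, so the series gives no direct precedent. Compound 1 also lacks isopropylamino and gives 0.024 in this assay, although it differs elsewhere too. On that basis, a modest rise is expected, with a 2.2-fold higher number from compound 3 to compound 4 (0.34 log units; beyond the scatter) as the estimated step. Compound 4 is expected at 0.022 (estimated range 0.011 to 0.045).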

Compound 4, unbound fraction: 0.027
The estimate for compound 4 lay 1.2-fold (0.09 log units) below the measured number, within the range that was stated.
By their numbers in this assay, from the lowest: compound 3; then compounds 1, 4 and 2 (each within the scatter of the next).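

In this assay, among these compounds, methyl in place of isopropylamino on a sulfonyl sulfur gives a 2.7-fold higher number from compound 3 to compound 4 (0.43 log units; beyond the scatter) and is the first single-place comparison. It shows that the group on this sulfur can shift the free fraction on the core of compound 3 by more than the scatter. No supporting measurement bears on why the step occurs.

This one pair does not separate the loss of the hydrogen-bond donor from the loss of the carbon atoms. On these data alone, how ethyl, cyclopropyl or plain amino on the same sulfur would read remains open.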